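The compounds below may be only part of what the source reports. "The series", "measured", "known", "first", "only" and "open" are said of these compounds alone.

Working notes on the chlorophenyl series in an ADME assay on MCF-10A cells (Homo sapiens) for inhibition, with a stated time of 48 h (a higher number here means a weaker inhibitor, a lower number a stronger inhibitor), follow. Compound 1 `O=C(Nc1ccc(Cl)cc1)N1CCC[C@H]1c1nc(-c2ccccc2Cl)no1` carries 2-chlorophenyl and reads > 50000 nM as a limit, not a number. Compound 2 `O=C(Nc1ccc(Cl)cc1)N1CCC[C@H]1c1nc(-c2cccc(Cl)c2)no1` carries 3-chlorophenyl and reads > 50000 nM as a limit as well. Compound 3 `O=C(Nc1ccc(Cl)cc1)N1CCC[C@H]1c1nc(-c2ccc(Cl)cc2)no1` carries 4-chlorophenyl and reads > 50000 nM as a limit too. Compound 3 therefore has no number of its own and shares its place with the other two: the limit of > 50000 nM in this assay, at which 3 of the 3 values shown sit.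

Compound 4 `N#Cc1ccc(-c2noc([C@@H]3CCCN3C(=O)Nc3ccc(Cl)cc3)n2)cc1` keeps the core of compound 3 and has cyano in place of chloro on an aromatic carbon, para to a large group (cyano in place of chloro on an aromatic carbon). The measured steps nearest to this change are a step that the two limits leave unreadable from compound 1 to compound 3 and a step that the two limits leave unreadable from compound 2 to compound 3 and also a step that the two limits leave unreadable from compound 1 to compound 2, so none gives a size to carry over, and none involves cyano. Within the data shown here, the data show no compound with a readable value in this assay. Compound 3 stays at > 50000 nM as a limit, and that is the only anchor for the expectation. No step beyond the scatter can be forecast, and no direction is expected. The expected outcome is a number no higher from compound 3 to compound 4 (the limit leaves the size open) as an estimate only. The estimate for compound 4 is 50000 nM with an expected range from 20000 nM to 80000 nM and most likely only a limit will be reported.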

Compound 4, half-maximal inhibitory concentration: > 50000 nM
Compound 4: no number, only a limit (the forecaster's own chance of this, stated with the estimate: 85%); the middle value lies on the limit itself.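

No step from compound 1, compound 2 or compound 3 to compound 4 can be read in this assay: the limit of > 50000 nM in this assay, at which 4 of the 4 values shown sit.

The compounds shown leave open whether any of the four has a readable half-maximal inhibitory concentration in this assay, and so how the chlorophenyl and 4-cyanophenyl variants compare in size or direction.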